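Replacing a pyridyl ring with methoxyphenyl on the biaryl

This account rests on a few compounds, and the source may have more. Where it says the series, first, only, none or still open, it means among the compounds named here.

Of the compounds shown here, three have been measured in a functional assay for agonist activity at G protein-coupled receptor 88 (Homo sapiens), read by HTRF and cAMP accumulation; a higher number here means that more compound is needed for the effect, a lower number that less compound is needed. Compound 1 `CCC(C)CNCCN(C(=O)[C@@H]1C[C@H]1c1ccccc1)c1ccc(-c2ccccc2)cc1` gives 4.7 nM, compound 2 `CC[C@H](C)[C@H](N)CN(C(=O)[C@@H]1C[C@H]1c1ccc(Cl)cc1)c1ccc(-c2ccccc2)cc1` gives 4300 nM, and compound 3 `CC(C)C[C@H](N)CN(C(=O)[C@@H]1C[C@H]1c1ccccc1)c1ccc(-c2cccnc2)cc1` gives 10000 nM. Compound 3 therefore stands at the highest number of the three, with compound 2 as its nearest neighbour and compound 1 far below it. Compound 4 `COc1ccc(-c2ccc(N(C[C@@H](N)CC(C)C)C(=O)[C@@H]3C[C@H]3c3ccccc3)cc2)cc1` has not been measured yet. It differs from compound 3 in one place: 4-methoxyphenyl in place of pyridin-3-yl on an aromatic carbon. Within the data shown here, no measured pair shows this exact change, so its effect can only be judged from the surrounding numbers. Compound 2, which also carries a primary amine on its side chain but keeps a carbon-only ring in the outer position, sits below compound 3, and this suggests that compound 4 is expected to move toward a lower number in this assay, by a step of about a 2.9-fold lower number from compound 3 to compound 4 (0.46 log units; beyond the scatter). Compound 4 is accordingly estimated at 3500 nM, with a likely range from 1000 nM to 12000 nM.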

Compound 4, half-maximal effective concentration: 330 nM
The estimate for compound 4 lay 11-fold (1.03 log units) above the measured number; measured number below the stated range.
By their numbers in this assay, from the lowest: compound 1; then compound 4; then compound 2; then compound 3.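

In this assay, among these compounds, the exchange of pyridin-3-yl for 4-methoxyphenyl, para to a large group, gives a 30-fold lower number from compound 3 to compound 4 (1.48 log units; beyond the scatter) and shows for the first time that this aromatic position strongly affects the number when everything else in the molecule stays fixed. The two groups have the same counts of hydrogen-bond donors and acceptors and carry no net charge, so these counts do not distinguish them, although the entering group is larger and its ring is carbon only. No evidence is available to explain the step.

Going by these compounds, it remains open whether the gain comes from the methoxy group, from the loss of the ring nitrogen, or from both. A plain phenyl, a 4-ethoxyphenyl or a 4-hydroxyphenyl on the same side chain would help separate these possibilities.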